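The compounds below may be only part of what the source reports. "The series", "measured", "known", "first", "only" and "open" are said of these compounds alone.

Working notes on the series, read in an ADME assay on microsomes from liver (Rattus norvegicus) for metabolic stability, read by LC-MS, with a stated time of 10 min, tested at 0.5 uM; on this read-out lower numbers stand for a less stable compound and higher numbers for a more stable compound. Among the measured compounds shown here, compound 1 `c1ccc2c(c1)CN[C@@H](CN(CC1CCNCC1)[C@H]1CCCc3cccnc31)C2` gives 65% and compound 2 `c1ccc2c(c1)CN[C@@H](CN(CCC1CCNCC1)[C@H]1CCCc3cccnc31)C2` gives 17%, so compound 2 holds the lower of the two numbers, with compound 1 as its only neighbour on this scale. Compound 3 `CCN1CCN(CCCN(C[C@H]2Cc3ccccc3CN2)[C@H]2CCCc3cccnc32)CC1` has no number yet. The change is (4-ethylpiperazin-1-yl)methyl in place of piperidin-4-yl on a saturated chain carbon, two bonds along the chain from an amine nitrogen. Cut one bond further out, it reads 2-(piperidin-4-yl)ethyl to 3-(4-ethylpiperazin-1-yl)propyl. For the measured compounds named here, one measured step bears on it: a number 48 percentage points lower from compound 1 to compound 2 (beyond the scatter), a large fall beyond the scatter, with (piperidin-4-yl)methyl in place of piperidin-4-yl. That single step is thin evidence for a change that also swaps the ring. With compound 2 at 17%, little room remains for another fall of that size, so a slight downward lean is expected, probably not beyond the scatter. The expected step is a number 4 percentage points lower from compound 2 to compound 3 (within the scatter). Compound 3 is estimated at 13%, with an expected range of 4% to 32%.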

Compound 3, percent of the compound remaining: 1%
The estimate for compound 3 lay 12 percentage points above the measured number, outside the stated range (below it).
By their numbers in this assay, from the lowest: compound 3; then compound 2; then compound 1.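

In this assay the (4-ethylpiperazin-1-yl)methyl group in place of piperidin-4-yl, on a saturated chain carbon, two bonds along the chain from an amine nitrogen, gives a number 16 percentage points lower from compound 2 to compound 3 (beyond the scatter) and so takes the series lower still, even from a number that was already low. Taken from the shortest member, 2-(4-ethylpiperazin-1-yl)ethyl in place of piperidin-4-yl on a saturated chain carbon bound to an amine nitrogen gives a number 64 percentage points lower from compound 1 to compound 3 (beyond the scatter), and across these three compounds the number falls with each enlargement of the group, with none going against that order. No measurement at hand accounts for either fall.

Compound 3 differs from compound 2 in chain length, ring and ring substituent all at once, so the step cannot be divided among the extra chain carbon, the second ring nitrogen and the ethyl group. From the compounds shown here alone, a 3-(piperidin-4-yl)propyl group, a 2-(piperazin-1-yl)ethyl group or a 2-(4-ethylpiperazin-1-yl)ethyl group on the chain of compound 2 would each bear on that division, and what a shorter chain carrying the ethylpiperazine would give remains open.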